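Replacing the (3-chloropropyl)amino group of compound 3

This account rests on a few compounds, and the source may have more. Where it says the series, first, only, none or still open, it means among the compounds named here.

In a functional assay on MCF7 cells (Homo sapiens) for antiproliferative activity, with a stated time of 48 h (a lower number here means a stronger inhibitor, a higher number a weaker inhibitor), compound 1 (`CCCCCc1cccc(NC(=O)NCCCCl)c1`) gives 26000 nM. Compound 2 (`CCCCC(O)c1cccc(NC(=O)NCCCCl)c1`) reaches only a limit, > 100000 nM. Compound 3 (`CCCCC(OC)c1cccc(NC(=O)NCCCCl)c1`) gives 50000 nM, and a 1.9-fold higher number from compound 1 to compound 3 (0.28 log units; within the scatter) places it level with compound 1. Adding hydroxy instead gave an at least 3.8-fold higher number from compound 1 to compound 2 (0.58 log units; beyond the scatter), while methylating that oxygen gave an at least 2.0-fold lower number from compound 2 to compound 3 (0.30 log units; that floor lies within the scatter).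

Compound 4 (`CCCCC(OC)c1cccc(NC(=O)CCl)c1`) has chloromethyl in place of (3-chloropropyl)amino on a carbonyl carbon. For the measured compounds named here, none of the measured steps touches that place, so they offer no guide to its size or direction. The expectation therefore stays anchored on compound 3 at 50000 nM, with no shift beyond the scatter. The estimated step is a 1.4-fold lower number from compound 3 to compound 4 (0.15 log units; within the scatter). For compound 4 the estimated value is 35000 nM, with an expected range of 10000 nM to 100000 nM.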

Compound 4, half-maximal inhibitory concentration: 12000 nM
Estimate against measurement, compound 4: 2.9-fold (0.46 log units) above, within the range that was stated.
By their numbers in this assay, from the lowest: compound 4; then compounds 1 and 3 (each within the scatter of the next). At a limit, above all of these: compound 2.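

For the compounds shown here, the carbonyl carbon proves a more responsive place than the saturated chain carbon: in this assay, chloromethyl in place of (3-chloropropyl)amino gives a 4.2-fold lower number from compound 3 to compound 4 (0.62 log units; beyond the scatter), whereas no earlier step lowered the number beyond the scatter. The swap shortens the group from 5 heavy atoms to 2 and removes its nitrogen with its hydrogen-bond donor, but nothing shown separates these differences or explains the shift.

Going by these compounds, whether the chlorine matters stays open, since a plain methyl group or a longer chloroalkyl chain on the carbonyl carbon would be needed to test it. Also open, on these data alone, is whether the same swap would lower the number on the core of compound 1.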